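Nitrate-bearing cinnamate esters: methoxy to hydroxy on the ring

This account rests on a few compounds, and the source may have more. Where it says the series, first, only, none or still open, it means among the compounds named here.

Measured so far:
Compound 1, `COc1cc(/C=C/C(=O)OCCCO[N+](=O)[O-])ccc1OCCCO[N+](=O)[O-]`: in a functional assay on NCI-H1299 cells (Homo sapiens) for cytotoxicity, read by resazurin assay, with a stated time of 72 h (on this read-out higher numbers stand for weaker inhibition and lower numbers for stronger inhibition), compound 1 gives > 50000 nM, a limit of the assay rather than a number.
Compound 2, `O=C(/C=C/c1ccc(OCCCCCCO[N+](=O)[O-])c(O)c1)OCCCCCCO[N+](=O)[O-]`: in this assay compound 2 gives > 50000 nM, again a limit of the assay.
Compound 3, `COc1cc(/C=C/C(=O)OCCCCCCO[N+](=O)[O-])ccc1OCCCCCCO[N+](=O)[O-]`: in this assay compound 3 gives > 50000 nM, also a limit of the assay.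

Among the compounds with values here, the one change made between measured compounds is hydrogen in place of methyl on an oxygen on an aromatic ring. Within the data shown here, the step it produced, a step that the two limits leave unreadable from compound 3 to compound 2, cannot be read, since both ends sit at the limit; the only evidence on it is the limit of > 50000 nM in this assay, at which 3 of the 3 values shown sit.

Compound 4, `O=C(/C=C/c1ccc(OCCCO[N+](=O)[O-])c(O)c1)OCCCO[N+](=O)[O-]`, is not yet measured in this assay. It stands to compound 1 as compound 2 stands to compound 3: the change is hydrogen in place of methyl on an oxygen on an aromatic ring, the same change at the same place. The difference between the cores of compound 1 and compound 3 is not broken down here.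

Because the limit of > 50000 nM in this assay, at which 3 of the 3 values shown sit, holds for every measured compound, there is no readable step on which to build a directional expectation for compound 4. The expected step that the limit leaves unreadable from compound 1 to compound 4 is therefore taken as flat, resting on (the limit of > 50000 nM in this assay, at which 3 of the 3 values shown sit). For compound 4 the estimate is 60000 nM, with the expected range running from 20000 nM to 200000 nM, and a high chance that the assay again reports only a limit.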

Compound 4, half-maximal inhibitory concentration: > 50000 nM
Compound 4: a limit, no number (the forecaster's own chance of this, stated with the estimate: 85%); the middle value is on the limit's open side.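

The step from compound 1 to compound 4, methoxy to hydroxy, cannot be read, since compound 1 and compound 4 both give only a limit in this assay: the limit of > 50000 nM in this assay, at which 4 of the 4 values shown sit.

The compounds shown leave open whether methoxy to hydroxy has any effect on the read-out in this assay, and whether any member of this series gives a number there rather than a limit.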